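The source may hold more compounds than are shown below. What is called first, only, known or untested is meant among the compounds shown, and "the series" means these compounds.

In a functional assay on A549 cells (Homo sapiens) for antiproliferative activity, read by MTT assay, with a stated time of 48 h (on this read-out higher numbers stand for weaker inhibition of growth and lower numbers for stronger inhibition of growth), compound 2 (`COC(=O)N1N=C(c2ccc(OC)cc2)CC1c1cc(OC)c(OC)c(OC)c1`) gives 3400 nM and compound 1 (`COC(=O)N1N=C(c2cccc(OC)c2)CC1c1cc(OC)c(OC)c(OC)c1`) gives 2590 nM. Within the data shown here, these are the only two values so far, and they lie within the usual scatter of each other.

Compound 3 (`COC(=O)N1N=C(c2cccc(O)c2)CC1c1cc(OC)c(OC)c(OC)c1`) has not yet been measured. It differs from compound 2 on a carbon with a double bond to nitrogen, where 3-hydroxyphenyl takes the place of 4-methoxyphenyl (3-hydroxyphenyl in place of 4-methoxyphenyl on a carbon with a double bond to nitrogen). Among the measured compounds shown here, the one measured step at this place puts 4-methoxyphenyl in place of 3-methoxyphenyl (a 1.3-fold higher number from compound 1 to compound 2 (0.12 log units; within the scatter)) and is small. For the measured compounds named here, no measured compound carries 3-hydroxyphenyl, so this step is only a weak guide. Resting on it, a step no larger than the scatter and with no favoured direction is expected in this assay for this change. The expected step is small (a 1.1-fold lower number from compound 2 to compound 3 (0.05 log units; within the scatter)). For compound 3 the expected value is 3000 nM with 1000 nM and 9000 nM as the estimated ends of its range.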

Compound 3, concentration for 50% growth inhibition: 3170 nM
Compound 3: the middle estimate sits 1.1-fold (0.02 log units) below what was measured, and the stated range covers the measured number.
By their numbers in this assay, from the lowest: compounds 1, 3 and 2 (each within the scatter of the next).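

In this assay, hydrogen in place of methyl on the oxygen on the aromatic ring gives a 1.2-fold higher number from compound 1 to compound 3 (0.09 log units; within the scatter), so this position has now been tested with a hydroxyl as well as a methoxy group. Moving to 3-hydroxyphenyl from 4-methoxyphenyl brings in a hydrogen-bond donor and gives a 1.1-fold lower number from compound 2 to compound 3 (0.03 log units; within the scatter), so across these three compounds neither the added donor nor the changed place of the oxygen moves the number beyond the scatter. No other measurement available here helps to interpret this result.

As far as these compounds go, all three compounds carry an oxygen on this phenyl ring, so the effect of an amine, a chlorine atom or a longer chain such as butoxy remains open. Also open, from the compounds shown here alone, is whether any group at this position can move the number beyond the scatter.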